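Returning to a fluorinated aryl group: an expected maximal response

The source may report more compounds than this note shows. Statements on the series, on what has been measured and on what is new or still open speak of the compounds shown alone.

Measured so far:
compound 1 `N#Cc1c(N2CCC(c3cccc(F)c3)CC2)ccn(CC2CC2)c1=O`: 268%
compound 2 `COc1ccc(C2CCN(c3ccn(CC4CC4)c(=O)c3C#N)CC2)cc1`: 257%

In a functional assay on CHO cells for positive allosteric modulation of metabotropic glutamate receptor 2 (Homo sapiens), with a stated time of 30 min (on this read-out lower numbers stand for smaller maximal responses and higher numbers for larger maximal responses), compound 1 gives 268% and compound 2 gives 257%. Within the data shown here, compound 2 stands lowest of the two measured values; the only measured step, a number 11 percentage points lower from compound 1 to compound 2 (beyond the scatter), is modest though beyond the scatter.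

Compound 3 `N#Cc1c(N2CCC(c3cc(F)cc(F)c3)CC2)ccn(CC2CC2)c1=O` differs from compound 2 by 3,5-difluorophenyl in place of 4-methoxyphenyl on a saturated ring carbon. Among the measured compounds shown here, only that one step bears on this change: there a fluorophenyl gave way to 4-methoxyphenyl, here 4-methoxyphenyl gives way to a fluorophenyl again, so a modest rise is expected. Compound 3 is expected to move by a number 9 percentage points higher from compound 2 to compound 3 (within the scatter), to an estimated 266%, within 235% to 297%.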

Compound 3, largest response reached (Emax), in percent of the reference or control that the assay uses: 234%
For compound 3 the middle estimate is 32 percentage points above the measured one, and the stated range ends above it.
By their numbers in this assay, from the lowest: compound 3; then compound 2; then compound 1.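

Fluorine on the aryl group does not by itself give a high maximal response: in this assay the change to 3,5-difluorophenyl on this saturated ring carbon gives a number 23 percentage points lower from compound 2 to compound 3 (beyond the scatter) rather than a rise. One further fluoro on the aromatic ring gives a number 34 percentage points lower from compound 1 to compound 3 (beyond the scatter), so the number of fluoro groups on this ring matters, at least in this pair. Nothing measured here explains either fall. Still open, going by these compounds, is how the response would change with an amine or a carboxylic acid on this aryl ring. On these data alone, a longer chain in place of the aryl group is equally open.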